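The source may hold more compounds than are shown below. What is called first, only, known or untested is meant among the compounds shown, and "the series" means these compounds.

Measured in an in vitro ADME assay on microsomes from liver (Homo sapiens) for metabolic stability; on this read-out lower numbers stand for a shorter-lived compound and higher numbers for a longer-lived compound:
- Compound 1 `CS(=O)(=O)Nc1ccc2c(c1)S(=O)(=O)N=C(C1=C(O)[C@H]3CCC[C@H]3N(Cc3ccc(F)c(F)c3)C1=O)N2`: > 1 h
- Compound 2 `CS(=O)(=O)Nc1ccc2c(c1)S(=O)(=O)N=C(c1c(O)c3cccn3n(Cc3ccc(F)cc3)c1=O)N2`: > 1 h
- Compound 3 `CS(=O)(=O)Nc1ccc2c(c1)S(=O)(=O)N=C(C1=C(O)C3CCCCC3N(Cc3ccc(F)cc3)C1=O)N2`: > 1 h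

Compound 1 gives > 1 h, which is a limit and not a number. It has company, as the series shows (the limit of > 1 h in this assay, at which 3 of the 3 values shown sit).

Compound 4 `CS(=O)(=O)Nc1ccc2c(c1)S(=O)(=O)N=C(C1=C(O)[C@H]3CCC[C@H]3N(Cc3ccc(C(F)(F)F)cc3)C1=O)N2` carries 4-(trifluoromethyl)phenyl in place of the 3,4-difluorophenyl of compound 1, on a saturated chain carbon bound to an amide-type nitrogen in a ring (4-(trifluoromethyl)phenyl in place of 3,4-difluorophenyl on a saturated chain carbon bound to an amide-type nitrogen in a ring). For the measured compounds named here, no measured pair differs in one place, so the series offers no direct precedent for this change. In this assay, no step beyond the scatter is expected, and no direction is favoured. The expected change is a step that the limit leaves unreadable from compound 1 to compound 4. Compound 4 is estimated at 1.5 h, with an expected range from 0.7 h to 3 h.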

Compound 4, half-life: > 1 h
Compound 4 was reported as a limit (the forecaster's own chance of this, stated with the estimate: 80%); the middle value lies beyond the limit too.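

For the compounds shown here, compound 1 and compound 4 each stand at a limit of the assay, so no step between them can be read. The compounds shown leave open the actual half-life of each and whether 4-(trifluoromethyl)phenyl in place of 3,4-difluorophenyl changes it.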